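Triazole-Linked Dibenzyloxy Compounds and Cell Viability

The source may hold more compounds than are shown below. What is called first, only, known or untested is meant among the compounds shown, and "the series" means these compounds.

Measured compounds:
Compound 1, `O=C1O/C(=C\Cn2cc(Cc3ccccc3)nn2)C(OCc2ccccc2)=C1OCc1ccccc1`, gives 70000 nM.
Compound 2, `O=C1NC(O)(CCn2cc(C3=CCCCC3)nn2)C(OCc2ccccc2)=C1OCc1ccccc1`, gives 70000 nM.
Compound 3, `COC1=C(OC)C(O)(CCn2cc(-c3ccccc3)nn2)NC1=O`, gives 62000 nM.

All three numbers come from an ADME assay on HEK293 cells (Homo sapiens) for cytotoxicity, read by MTT assay, with a stated time of 24 h; on this read-out lower numbers stand for stronger inhibition and higher numbers for weaker inhibition. On this read-out compound 1 stands level with compound 2 at the digits shown, and together they give the highest of the three numbers; compound 3 lies only slightly apart from compound 1, a gap that sits within the usual scatter of such measurements. In short, the three measured compounds cannot be told apart on this read-out, and each of them affects cell viability only at high concentration.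

Compound 4, `O=C1O/C(=C\Cn2cc(C3=CCCCC3)nn2)C(OCc2ccccc2)=C1OCc1ccccc1`, has not yet been measured in this assay . It differs from compound 1 in a single place: cyclohex-1-en-1-yl in place of benzyl on an aromatic carbon. Compound 2 already carries a cyclohex-1-en-1-yl group on its triazole, though on a different core, and its value is the same as that of compound 1 at the digits shown.

Among the measured compounds shown here, no step between two measured compounds covers this exact change, so the expectation rests on the flat picture across compounds 1, 2 and 3. Within this assay, the step of no change at the digits printed from compound 1 to compound 4 (within the scatter) is expected to be none beyond the scatter. Compound 4 is therefore estimated to give 70000 nM, with a range from 35000 nM to 140000 nM.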

Compound 4, half-maximal inhibitory concentration: > 100000 nM
Compound 4: a limit, no number; the forecaster's own chance of this, stated with the estimate: 30%; middle value at least 1.4-fold (0.15 log units) from the limit.
By their numbers in this assay, from the lowest: compounds 3, 1 and 2 (each within the scatter of the next). At a limit, above all of these: compound 4.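

Compound 4 gives > 100000 nM in this assay, and this is a limit of the assay and not a number. Among the compounds shown here, this pair is the first direct look at a single change on one shared core: cyclohex-1-en-1-yl in place of benzyl on an aromatic carbon of the five-membered aromatic ring with 3 nitrogen gives an at least 1.4-fold higher number from compound 1 to compound 4 (0.15 log units; that floor lies within the scatter), so trading the aromatic ring of benzyl for a non-aromatic ring with one double bond brings no stronger effect on the cells. On these data alone, the step is only a floor, and the true size of the change stays unknown, so the pair does not show a real rise beyond the scatter: the limit of > 100000 nM in this assay, at which 1 of the 4 values shown sits.

The compounds shown leave open whether benzyl and cyclohex-1-en-1-yl would compare in the same way on the core of compound 2, where only the second of these groups appears. They also leave open how this place on the ring would respond to a group of a different kind, such as an amine, a carboxylic acid or a longer alkyl chain.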